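Compound 3: 3-chlorophenyl on the shared core

The source may report more compounds than this note shows. Statements on the series, on what has been measured and on what is new or still open speak of the compounds shown alone.

Measured so far in a functional assay on SK-OV-3 cells (Homo sapiens) for cytotoxicity (on this read-out higher numbers stand for weaker inhibition and lower numbers for stronger inhibition), for two compounds:
compound 1 `C=C/C=C\[C@H](C)[C@H](OC(N)=O)[C@@H](C)[C@H](O)[C@@H](C)C/C(C)=C\[C@H](C)[C@@H](O)[C@@H](C)/C=C\CCc1cccc(O)c1C` gives 270 nM
compound 2 `C=C/C=C\[C@H](C)[C@H](OC(N)=O)[C@@H](C)[C@H](O)[C@@H](C)C/C(C)=C\[C@H](C)[C@@H](O)[C@@H](C)/C=C\CCc1ccc(C)c(O)c1` gives 410 nM

Compound 2, at 410 nM, has one measured neighbour, and the two values cannot be told apart. Among the measured compounds shown here, the only measured step is a 1.5-fold higher number from compound 1 to compound 2 (0.18 log units; within the scatter). Compound 3 `C=C/C=C\[C@H](C)[C@H](OC(N)=O)[C@@H](C)[C@H](O)[C@@H](C)C/C(C)=C\[C@H](C)[C@@H](O)[C@@H](C)/C=C\CCc1cccc(Cl)c1` is still unmeasured, and the change to it is 3-chlorophenyl in place of 3-hydroxy-4-methylphenyl on a saturated chain carbon, two bonds along the chain from a double-bonded chain carbon. In words, 3-chlorophenyl stands in place of 3-hydroxy-4-methylphenyl. For the measured compounds named here, the measured step only exchanges 3-hydroxy-2-methylphenyl for 3-hydroxy-4-methylphenyl, and no measured compound lacks the hydroxy group or carries chlorine. That step therefore bears on the new change only weakly and indicates no direction. In this assay, no step beyond the scatter is expected, though with wide uncertainty. The expected change is a 1.2-fold higher number from compound 2 to compound 3 (0.09 log units; within the scatter). For compound 3 the estimated value is 500 nM, with an expected range of 150 nM to 1600 nM.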

Compound 3, half-maximal inhibitory concentration: 380 nM
Compound 3: the middle estimate sits 1.3-fold (0.12 log units) above what was measured; low and high end bracket the measured number.
By their numbers in this assay, from the lowest: compounds 1, 3 and 2 (each within the scatter of the next).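

In this assay, the first ring here without a hydroxy or a methyl group gives a 1.1-fold lower number from compound 2 to compound 3 (0.03 log units; within the scatter) and a 1.4-fold higher number from compound 1 to compound 3 (0.15 log units; within the scatter). At this position on a saturated chain carbon, then, neither group is needed to keep the value within the scatter of compound 1 and compound 2, and 3-chlorophenyl serves as well as either hydroxy-methyl-substituted ring. No supporting data on the three compounds account for this result.

Compound 3 exchanges the hydroxy group, the methyl group and chlorine in a single change, so the contribution of each remains unseparated. Also open, on these data alone, is whether the position keeps this range with an amine or a carboxylic acid on the ring, or with a chain longer than 2-(3-chlorophenyl)ethyl.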